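Acetoxy to chloro on two related cores

The source may report more compounds than this note shows. Statements on the series, on what has been measured and on what is new or still open speak of the compounds shown alone.

Compound 1 `CC(=O)OCCc1c(C)[nH]c(=O)[nH]c1=O` and compound 2 `COc1nc(C)c(CCOC(C)=O)c(OC)n1` carry the same acetoxy chain on different cores; the difference between the two cores is not broken down here. Among the compounds with values here, in a functional assay on SW-620 cells (Homo sapiens) for antiproliferative activity, read by MTT assay, with a stated time of 24 h (on this read-out higher numbers stand for weaker inhibition and lower numbers for stronger inhibition), compound 2 gives 44000 nM, the only number among the three measured values. For compound 1 the result is a limit of the assay, > 100000 nM. Compound 3 `Cc1[nH]c(=O)[nH]c(=O)c1CCCl` is compound 1 with chloro in place of acetoxy on a saturated chain carbon, two bonds along the chain from an aromatic carbon. For compound 3 the result is again a limit of the assay, > 100000 nM. The step that the two limits leave unreadable from compound 1 to compound 3 is therefore unreadable because the limit of > 100000 nM in this assay, at which 2 of the 3 values shown sit, covers both ends of it. Compound 4 `COc1nc(C)c(CCCl)c(OC)n1` is compound 2 with chloro in place of acetoxy on a saturated chain carbon, two bonds along the chain from an aromatic carbon, the same change made on the other core. The measured pair gives no size for this change, so the expectation for compound 4 rests on compound 2 at 44000 nM alone. The step of a 1.4-fold higher number from compound 2 to compound 4 (0.13 log units; within the scatter) is expected to be small. Compound 4 is expected to give about 60000 nM in this assay, within 15000 nM to 250000 nM.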

Compound 4, half-maximal inhibitory concentration: > 100000 nM
Compound 4: no number, only a limit; the forecaster's own chance of this, stated with the estimate: 40%; middle value at least 1.6-fold (0.22 log units) from the limit.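

In this assay compound 4 gives > 100000 nM, a limit of the assay and not a number. On the core of compound 2, chloro in place of acetoxy gives an at least 2.2-fold higher number from compound 2 to compound 4 (0.35 log units; beyond the scatter), so the change weakens inhibition on this core by an amount with a lower bound but no upper one. The matching step on the core of compound 1 cannot be read, so the pair of cores does not show whether the change carries over from one to the other, or with what size: the limit of > 100000 nM in this assay, at which 3 of the 4 values shown sit.

Still open, as far as these compounds go, is how far compound 4 really lies from compound 2, and whether any replacement of acetoxy holds the activity seen for compound 2. Also open, from the compounds shown here alone, is how an amine in place of acetoxy, on a saturated chain carbon, two bonds along the chain from an aromatic carbon, would read on the core of compound 2, the only core here with a number to compare against.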